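This account rests on a few compounds, and the source may have more. Where it says the series, first, only, none or still open, it means among the compounds named here.

Values in a functional assay on CCRF-CEM cells (Homo sapiens) for inhibition, read by MTT assay, with a stated time of 72 h; a lower number here means a stronger inhibitor, a higher number a weaker inhibitor:
compound 1 `COc1cc(NC(C)CCCNC(=O)Nc2cccc(Cl)c2)c2ncccc2c1`: 22000 nM
compound 2 `COc1cc(NC(C)CCCNC(=O)Nc2ccc(Br)cc2)c2ncccc2c1`: 23000 nM
compound 3 `COc1cc(NC(C)CCCNC(=O)NNC(=O)Nc2ccc(Br)cc2)c2ncccc2c1`: 110000 nM

Compound 3 has the highest number of the three and is the weakest inhibitor in this small set, since both of its steps are beyond the scatter: a 5.0-fold higher number from compound 1 to compound 3 (0.70 log units; beyond the scatter), and a 4.8-fold higher number from compound 2 to compound 3 (0.68 log units; beyond the scatter). The next compound to consider is compound 4 `COc1cc(NC(C)CCCNC(=O)Nc2ccc(Cl)cc2)c2ncccc2c1`. It carries 4-chlorophenyl in place of ((4-bromophenyl)carbamoyl)amino on an amide-type nitrogen.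

This puts a halogen-bearing phenyl group on that nitrogen, as in compound 1 and compound 2. Those two compounds show no difference beyond the scatter, a 1.0-fold higher number from compound 1 to compound 2 (0.02 log units; within the scatter), although their groups differ in both halogen and ring position. Going by the values given here, no measured compound carries 4-chlorophenyl itself, so the comparison is indirect and rests on only these two neighbours. The two modest steps to compound 3 are therefore expected to run in reverse, with a similar size and towards a lower number. In this assay the expected step is a 5.0-fold lower number from compound 3 to compound 4 (0.70 log units; beyond the scatter). Compound 4 is estimated at 22000 nM, with an expected range from 12000 nM to 40000 nM.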

Compound 4, half-maximal inhibitory concentration: 24000 nM
Estimate against measurement, compound 4: 1.1-fold (0.04 log units) below; the measured number falls inside the stated range.
By their numbers in this assay, from the lowest: compounds 1, 2 and 4 (each within the scatter of the next); then compound 3.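

In this assay, the step back from the longer group is now seen with a third halogen-bearing phenyl group on the amide-type nitrogen (a 4.6-fold lower number from compound 3 to compound 4 (0.66 log units; beyond the scatter)), so compound 3 stands apart from compound 1, compound 2 and compound 4. The earlier comparison of compound 1 and compound 2 changed the halogen and its ring position together, whereas compound 4 allows each change to be read alone: chloro in place of bromo gives no change beyond the scatter (a 1.0-fold higher number from compound 2 to compound 4 (0.02 log units; within the scatter)), and neither does 4-chlorophenyl in place of 3-chlorophenyl (a 1.1-fold higher number from compound 1 to compound 4 (0.04 log units; within the scatter)). No outside information is available to explain these numbers.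

The compounds shown leave open whether a phenyl group bearing an amine, a carboxylic acid or a methoxy group in place of the halogen would depart from these three halogen-bearing compounds. They also leave open whether a longer chain would change the number, and whether the ((4-bromophenyl)carbamoyl)amino result would hold with a chlorine in place of the bromine.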